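The source may hold more compounds than are shown below. What is called first, only, known or untested is meant among the compounds shown, and "the series" means these compounds.

Compound 2 `COc1cccc(-c2nn3c(COc4ccnc5cc(OC)ccc45)nnc3s2)c1` gives 472 nM in a functional assay on EBC-1 cells (Homo sapiens) for antiproliferative activity, with a stated time of 72 h; a lower number here means a stronger inhibitor, a higher number a weaker inhibitor. Within the data shown here, it holds the higher of the two numbers known so far, yet its only neighbour, compound 1 `COc1ccc2c(OCc3nnc4sc(-c5cc[nH]c5)nn34)ccnc2c1`, sits at 353 nM, and the step of a 1.3-fold higher number from compound 1 to compound 2 (0.13 log units; within the scatter) is within the scatter, so the two stand together. Compound 3 `COc1ccc2c(OCc3nnc4sc(-c5ccc(F)cc5)nn34)ccnc2c1` is reached by the change (4-fluorophenyl in place of 3-methoxyphenyl on an aromatic carbon). Among the measured compounds shown here, the single measured step that bears on this position, from compound 1 to compound 2, exchanged one aromatic group for another at the same carbon and left the number essentially where it was. For the measured compounds named here, with that as the sole guide, compound 3 is expected to show no step beyond the scatter, and the estimated step of a 1.0-fold lower number from compound 2 to compound 3 (0.02 log units; within the scatter) is accordingly small. On this basis compound 3 is estimated at 450 nM, with a plausible range from 150 nM to 1400 nM.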

Compound 3, half-maximal inhibitory concentration: 187 nM
Compound 3: the middle estimate sits 2.4-fold (0.38 log units) above what was measured; the range from low to high includes it.
By their numbers in this assay, from the lowest: compounds 3, 1 and 2 (each within the scatter of the next, the first and the last beyond it).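

In this assay this carbon proves able to shift the number: the exchange gives a 2.5-fold lower number from compound 2 to compound 3 (0.40 log units; beyond the scatter) and so produces a modest step beyond the scatter, which the earlier exchange of aromatic groups did not. Set against the 1H-pyrrol-3-yl group, the same 4-fluorophenyl group gives a 1.9-fold lower number from compound 1 to compound 3 (0.28 log units; within the scatter) and stays within the scatter, so only the 3-methoxyphenyl and 4-fluorophenyl groups can be told apart, while compound 1 cannot be separated from either. No measurement offered here explains the step.

The compounds shown leave open whether the step follows the substituent or its ring position, a question that a 4-methoxyphenyl or 3-fluorophenyl group would address. They also leave open how an amine, a carboxylic acid or a longer alkyl chain would fare at this carbon.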